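Methyl to methoxy on a shared oxazole-fused core

The compounds below may be only part of what the source reports. "The series", "measured", "known", "first", "only" and "open" are said of these compounds alone.

Measured so far:
- Compound 1, `Cc1ccc(-c2nc3cccnc3o2)cc1`: 0%
- Compound 2, `Brc1cccc(-c2nc3ncccc3o2)c1`: 23%

Both compounds were tested in a functional assay on the whole organism for inhibition, with Rattus norvegicus as the target, at a dose of 30 mg/kg; a lower number here means less inhibition, a higher number more inhibition at the dose given (going by the name of the read-out). Compound 1 gives 0%, the lower of the two numbers. Compound 2 gives 23%, a difference that lies beyond the usual scatter of this kind of measurement, so compound 2 does show more inhibition than compound 1. For the measured compounds named here, no pair of measured compounds differs in only one place, so no single step has been measured yet.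

Compound 3, `COc1ccc(-c2nc3cccnc3o2)cc1`, has not been measured. It differs from compound 1 in one place: methoxy in place of methyl on an aromatic carbon. Going by the values given here, with no measured step available to lean on, the size of this change can only be guessed. Compound 1 sits at the bottom of the scale, so the number cannot fall; a modest rise, or none beyond the scatter, is the expectation. The step from compound 1 to compound 3 is therefore expected to be a number 10 percentage points higher from compound 1 to compound 3 (within the scatter). Compound 3 is expected to give about 10%, most likely between 0% and 35%.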

Compound 3, a percentage reported as inhibition, in the whole organism at one dose (the size of the read-out at that dose, not a potency): 29%
Compound 3: the middle estimate sits 19 percentage points below what was measured, and the stated range covers the measured number.
By their numbers in this assay, from the lowest: compound 1; then compounds 2 and 3 (each within the scatter of the next).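

In this assay the swap of methyl for methoxy on an aromatic carbon of the six-membered carbon ring gives a number 29 percentage points higher from compound 1 to compound 3 (beyond the scatter). For the compounds shown here, this is the first single change in the set that can be read on its own, and it shows that this position, para to a group of 9 heavy atoms, is not indifferent to what it carries: with the rest of the molecule untouched, this one exchange lifts the read-out off the bottom of the scale. No measurement at hand explains the rise.

From the compounds shown here alone, whether an ethoxy group, a hydroxyl or an amine on the same carbon would raise the number further or bring it back towards that of compound 1 stays open, as does whether methoxy would have the same effect on another carbon of that ring. Going by these compounds, the read-out gives the size of the inhibition at a single dose and not a potency, so how compound 3 would perform at other doses also remains unknown.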